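The source may hold more compounds than are shown below. What is called first, only, known or untested is meant among the compounds shown, and "the series" means these compounds.

Going by the values given here, compound 3 `COc1ccccc1OC(C)C1=NCCN1` gives 9770 nM in a functional assay on CHO cells for agonist activity at Alpha-2C adrenergic receptor (Homo sapiens) (a lower number here means that less compound is needed, a higher number that more compound is needed for the effect), the highest of the three numbers measured so far. Compound 1 `CC(C)Oc1ccccc1OC(C)C1=NCCN1` gives 100 nM and compound 2 `CC(Oc1ccccc1OC1CC1)C1=NCCN1` gives 47.9 nM, so there is a 98-fold higher number from compound 1 to compound 3 (1.99 log units; beyond the scatter) and a 200-fold higher number from compound 2 to compound 3 (2.31 log units; beyond the scatter), both large steps, whereas a 2.1-fold lower number from compound 1 to compound 2 (0.32 log units; beyond the scatter) is only modest. Compound 4 `CC(=O)c1ccccc1OC(C)C1=NCCN1` differs from compound 3 by acetyl in place of methoxy on an aromatic carbon. Among the compounds with values here, no measured step exchanges the methoxy for a group of a different kind; the large steps from compound 1 and compound 2 show only that the methoxy at this place goes with a weak effect. With no direct guide, the change is expected to be small but uncertain, so compound 4 is estimated at 5000 nM, between 700 nM and 30000 nM. That estimate means an expected 2.0-fold lower number from compound 3 to compound 4 (0.29 log units; within the scatter).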

Compound 4, half-maximal effective concentration: 200 nM
For compound 4 the middle estimate is 25-fold (1.40 log units) above the measured one; measured number outside the range, below it.
By their numbers in this assay, from the lowest: compound 2; then compounds 1 and 4 (each within the scatter of the next); then compound 3.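

At this place, the weak effect of compound 3 can be overcome by more than a larger ether: acetyl, which carries a carbonyl, gives a 49-fold lower number from compound 3 to compound 4 (1.69 log units; beyond the scatter) in this comparison. Acetyl in place of isopropoxy gives a 2.0-fold higher number from compound 1 to compound 4 (0.30 log units; within the scatter) and so cannot be told apart from it here, while acetyl in place of cyclopropyloxy gives a 4.2-fold higher number from compound 2 to compound 4 (0.62 log units; beyond the scatter) as a modest step. No measurement shown explains these differences. Going by these compounds, whether an amine or a carboxylic acid on this aromatic carbon would match acetyl or methoxy remains open, as does the effect of a longer chain in place of the acetyl.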